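Adding a Chlorine to the Anilide of Compound 1

The compounds below may be only part of what the source reports. "The series", "measured", "known", "first", "only" and "open" are said of these compounds alone.

For the measured compounds named here, compound 1 `CC1=C(C(=O)Nc2ccccc2)C(c2cn(-c3ccccc3)nc2-c2ccccc2)NC(=O)N1` gives the higher of the two numbers measured so far in a functional assay on MCF7 cells (Homo sapiens) for inhibition, read by sulforhodamine B assay, with a stated time of 24 h; on this read-out higher numbers stand for weaker inhibition of growth and lower numbers for stronger inhibition of growth: compound 1 gives 80600 nM, whereas compound 2 `CC1=C(C(=O)Nc2ccc(Cl)cc2)C(c2cn(-c3ccccc3)nc2-c2ccccc2)NC(=S)N1` gives 34700 nM. Compound 3 `CC1=C(C(=O)Nc2ccccc2Cl)C(c2cn(-c3ccccc3)nc2-c2ccccc2)NC(=O)N1` differs from compound 1 by chloro in place of hydrogen on an aromatic carbon, sitting ortho to a large group on the anilide ring. No single-change comparison is available to guide this step, so only a modest shift toward stronger growth inhibition is expected, possibly not beyond the scatter. Compound 3 is therefore estimated at 55000 nM, within 20000 nM to 150000 nM. The expected step is a 1.5-fold lower number from compound 1 to compound 3 (0.17 log units; within the scatter).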

Compound 3, concentration for 50% growth inhibition: 66600 nM
For compound 3 the middle estimate is 1.2-fold (0.08 log units) below the measured one; measured number inside the range.
By their numbers in this assay, from the lowest: compounds 2, 3 and 1 (each within the scatter of the next, the first and the last beyond it).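

For the compounds shown here, the step of a 1.2-fold lower number from compound 1 to compound 3 (0.08 log units; within the scatter) is the first single-change comparison in this assay, and it stays within the scatter. At this place, ortho to a large group, chloro in place of hydrogen therefore leaves growth inhibition effectively unchanged, so this one added atom gives no real gain here. Nothing measured here explains this result. The compounds shown leave open whether a larger or differently built group here, such as methoxy or an amine, would move the number beyond the scatter. They also leave open how chloro alone behaves on the other carbons of this ring.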